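The compounds below may be only part of what the source reports. "The series", "measured", "known", "first", "only" and "open" are said of these compounds alone.

Among the measured compounds shown here, compound 2 `COc1cccc(NC(=O)COc2cc(C)nc3ccc(OC)cc23)c1` carries the only plain number in this small set: in an ADME assay on HepG2 cells (Homo sapiens) for cytotoxicity, read by trypan blue exclusion, with a stated time of 48 h, in the presence of a further agent that is not named here (a lower number here means that less compound is tolerated, a higher number that more compound is tolerated), compound 2 gives 43000 nM. Compound 1 `COc1ccc2nc(C)cc(OCC(=O)Nc3ccccc3)c2c1` reaches only a limit, > 155000 nM. Compound 3 `COc1ccc2nc(C)cc(OCC(=O)Nc3ccc(OC)c(OC)c3)c2c1` likewise stops at a limit, > 131000 nM. Both neighbouring steps add a methoxy on an aromatic carbon: an at least 3.6-fold lower number from compound 1 to compound 2 (0.55 log units; beyond the scatter), and an at least 3.0-fold higher number from compound 2 to compound 3 (0.48 log units; beyond the scatter), the second one ending at the limit of > 131000 nM in this assay, at which 1 of the 3 values shown sits. Compound 4 `COc1cc(NC(=O)COc2cc(C)nc3ccc(OC)cc23)cc(OC)c1` differs from compound 2 by methoxy in place of hydrogen on an aromatic carbon. The step from compound 2 to compound 3, which also adds a methoxy, is the closer model. For compound 4 a higher number in this assay is therefore expected, a 2.8-fold higher number from compound 2 to compound 4 (0.45 log units; beyond the scatter). Compound 4 is estimated at 120000 nM, between 40000 nM and 250000 nM, with a fair chance that only a limit is reported.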

Compound 4, half-maximal cytotoxic concentration: > 131000 nM
Compound 4 gave a limit, no number; the forecaster's own chance of this, stated with the estimate: 60%; middle value at least 1.0-fold (0.03 log units) away from the limit.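

Adding a methoxy at the place meta to a large group and meta to a methoxy group on the six-membered aromatic ring gives an at least 3.0-fold higher number from compound 2 to compound 4 (0.48 log units; beyond the scatter) in this assay. Compound 4 therefore joins compound 3 in showing that a second methoxy on this ring, at either of two places, lifts the number, and the lower plain number of compound 2 is no general effect of methoxy on this ring. Compound 4 reaches a limit, not a number: the limit of > 131000 nM in this assay, at which 2 of the 4 values shown sit.

The limits leave the true order of compound 1, compound 3 and compound 4 open. Going by these compounds, whether an amine or a carboxylic acid at this place would behave like methoxy also stays open.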